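The compounds below may be only part of what the source reports. "The series", "measured", "known", "first", "only" and "open" are said of these compounds alone.

Measured so far in an assay on CHO cells for displacement of a labelled ligand from adenosine receptor A1 (Homo sapiens), read by scintillation counting, with a stated time of 120 min, tested at 1 uM; on this read-out higher numbers stand for more inhibition at the one concentration tested (going by the name of the read-out) and lower numbers for less inhibition:
- compound 1 `CC(=O)Nc1nc(C)nc2cn(-c3ccccc3)nc12`: 25%
- compound 2 `Cc1nc(NC(=O)Nc2ccccc2)c2nn(-c3ccccc3)cc2n1`: 1%

Going by the values given here, compound 2 gives the lower of the two numbers in this assay; the only other point is compound 1, and the step of a number 24 percentage points lower from compound 1 to compound 2 (beyond the scatter) lies beyond the scatter. Among the compounds with values here, that step is the one change measured so far on the carbonyl carbon and it is the only one that bears on the next compound.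

Compound 3 `COc1ccc(C(=O)Nc2nc(C)nc3cn(-c4ccccc4)nc23)cc1` differs from compound 2 by 4-methoxyphenyl in place of anilino on a carbonyl carbon. The change moves the carbonyl carbon back from an anilino neighbour to an aryl neighbour, so it undoes the part of the step from compound 1 to compound 2 that replaced a carbon substituent with a nitrogen one, while keeping an aromatic ring there. Within the data shown here, no step measures an aryl group directly on that carbonyl carbon, so the expectation is loose.

Compound 3 is expected to rise from compound 2 by a number 14 percentage points higher from compound 2 to compound 3 (beyond the scatter) in this assay, because compound 2 sits at 1% and the anilino group is what set it apart from compound 1. The estimate for compound 3 is 15%, within 0% to 40%.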

Compound 3, a percentage reported as inhibition, at one concentration (the size of the read-out at that concentration, not a potency): 4%
Compound 3: middle estimate off by 11 percentage points, on the high side; measured number inside the range.
By their numbers in this assay, from the lowest: compounds 2 and 3 (each within the scatter of the next); then compound 1.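

In this assay, 4-methoxyphenyl in place of anilino on a carbonyl carbon gives a number 3 percentage points higher from compound 2 to compound 3 (within the scatter), so exchanging the anilino nitrogen and its hydrogen-bond donor for an aryl group with a methoxy oxygen does not separate these two compounds. Compared with methyl at the same place, 4-methoxyphenyl gives a number 21 percentage points lower from compound 1 to compound 3 (beyond the scatter), which joins the earlier step of a number 24 percentage points lower from compound 1 to compound 2 (beyond the scatter): both groups carrying an aromatic ring on this carbonyl carbon now stand beyond the scatter from the methyl of compound 1, and neither of the two compounds goes against this. No measurement at hand bears on what lies behind these numbers.

The compounds shown leave open whether any group on this carbonyl carbon reads higher than methyl, such as ethyl, cyclopropyl or a longer alkyl chain, and whether unsubstituted phenyl reads differently from 4-methoxyphenyl. Also open, as far as these compounds go, is how the free amine on the shared core, without the carbonyl, compares with compound 1 in this assay.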